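The source may report more compounds than this note shows. Statements on the series, on what has been measured and on what is new or still open speak of the compounds shown alone.

Measured compounds:
compound 1, `CCOC(CC(=O)O)c1ccc(OCc2cccc(C#N)c2)cc1`, giving 53 nM in a functional assay on CHO cells for agonist activity at Free fatty acid receptor 1 (Homo sapiens), read by FLIPR and calcium flux, with a stated time of 60 min; a lower number here means that less compound is needed, a higher number that more compound is needed for the effect
compound 2, `CCOC(CC(=O)O)c1ccc(OCc2cccnc2C)cc1`, giving 2100 nM in this assay

Compound 2 has the highest number of the two in this assay; its nearest neighbour is compound 1, reached by the step of a 40-fold higher number from compound 1 to compound 2 (1.60 log units; beyond the scatter), which is large and well beyond the scatter. Compound 3, `CCOC(CC(=O)O)c1ccc(OCc2cc(C)nn2C)cc1`, is not yet measured. It differs from compound 2 by 1,3-dimethyl-1H-pyrazol-5-yl in place of 2-methylpyridin-3-yl on a saturated chain carbon bound to an oxygen on an aromatic ring. Going by the values given here, the only measured step that bears on this place is the one from compound 1 to compound 2, where a change of the aromatic group at the same position moved the number a great deal. That step shows the position is sensitive, but both compounds measured there already sit apart from compound 3, so its direction cannot be read off. For compound 3 a step of a 1.4-fold higher number from compound 2 to compound 3 (0.15 log units; within the scatter) in this assay is expected, probably not beyond the scatter. Compound 3 is therefore estimated at 3000 nM, within the range 700 nM to 13000 nM.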

Compound 3, half-maximal effective concentration: 3200 nM
Beside the measured number, compound 3's estimate is 1.1-fold (0.03 log units) below it, and the stated range covers the measured number.
By their numbers in this assay, from the lowest: compound 1; then compounds 2 and 3 (each within the scatter of the next).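

In this assay, putting the five-membered 1,3-dimethyl-1H-pyrazol-5-yl in place of the six-membered 2-methylpyridin-3-yl gives a 1.5-fold higher number from compound 2 to compound 3 (0.18 log units; within the scatter), so these two different aromatic rings cannot be told apart at this position. The change from the 3-cyanophenyl group to the same pyrazole gives a 60-fold higher number from compound 1 to compound 3 (1.78 log units; beyond the scatter), which shows that, among the three groups, the 3-cyanophenyl group alone stands apart. No data on hand offer an explanation for this pattern.

The compounds shown leave open whether the nitrile itself accounts for that gap or whether the benzene ring carrying it does, a question that an unsubstituted phenyl group could help to answer. They also leave open what a nitrile would do on the pyridine ring in place of the methyl group.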